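The source may report more compounds than this note shows. Statements on the series, on what has been measured and on what is new or still open speak of the compounds shown alone.

In a functional assay on ECa-109 cells (Homo sapiens) for inhibition, read by MTT assay, with a stated time of 72 h (on this read-out lower numbers stand for stronger inhibition and higher numbers for weaker inhibition), the three measured compounds stand as follows:
compound 1 `CC(C)c1ccc(-c2nc(SCc3cn(CC(=O)NC(=O)Nc4ccccn4)nn3)nc(Nc3cccc(Cl)c3)c2C#N)cc1` gives 13300 nM
compound 2 `CC(C)c1ccc(-c2nc(SCc3cn(CC(=O)NC(=O)Nc4ccccn4)nn3)nc(Nc3cccc([N+](=O)[O-])c3)c2C#N)cc1` gives 31300 nM
compound 3 `Cc1cccc(Nc2nc(SCc3cn(CC(=O)NC(=O)Nc4ccccn4)nn3)nc(-c3ccc(C(C)C)cc3)c2C#N)c1` gives 7320 nM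

Compound 1 holds the second highest of the three numbers. Its nearest neighbour is compound 3, reached by a 1.8-fold lower number from compound 1 to compound 3 (0.26 log units; within the scatter), a gap within the scatter. Its furthest is compound 2, reached by a 2.4-fold higher number from compound 1 to compound 2 (0.37 log units; beyond the scatter), a modest step beyond the scatter. Between the two outer compounds lies a 4.3-fold lower number from compound 2 to compound 3 (0.63 log units; beyond the scatter). All three differ only in the group on the aryl ring attached to the amino nitrogen of the shared core.

Compound 4 `CC(C)c1ccc(-c2nc(SCc3cn(CC(=O)NC(=O)Nc4ccccn4)nn3)nc(Nc3ccccc3O)c2C#N)cc1` continues this exchange: 2-hydroxyphenyl in place of 3-chlorophenyl on a nitrogen on an aromatic ring. Among the compounds with values here, no measured step introduces a hydroxyl, so the measured steps bear only in kind, not in direction: substituent exchanges on this ring have so far moved this assay by a 2.4-fold higher number from compound 1 to compound 2 (0.37 log units; beyond the scatter) and by a 1.8-fold lower number from compound 1 to compound 3 (0.26 log units; within the scatter), both modest at most. An exchange of this size in this assay is therefore expected to stay near compound 1, with no confident direction; the estimated step is a 1.1-fold higher number from compound 1 to compound 4 (0.05 log units; within the scatter). Compound 4 is expected to give about 15000 nM, within 6000 nM to 40000 nM.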

Compound 4, half-maximal inhibitory concentration: 7380 nM
Estimate against measurement, compound 4: 2.0-fold (0.31 log units) above; low and high end bracket the measured number.
By their numbers in this assay, from the lowest: compounds 3, 4 and 1 (each within the scatter of the next); then compound 2.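

In this assay, a hydroxyl-bearing aryl group on this nitrogen fits within the range already set by the non-hydroxylated groups: a 1.8-fold lower number from compound 1 to compound 4 (0.26 log units; within the scatter) and a 1.0-fold higher number from compound 3 to compound 4 (0.00 log units; within the scatter) are both inside the scatter, so compound 4 cannot be separated from either neighbour. Within the data shown here, only the exchange against 3-nitrophenyl clears the scatter, with a 4.2-fold lower number from compound 2 to compound 4 (0.63 log units; beyond the scatter), which leaves compound 2 as the one member set apart from the other three at this position. No supporting measurement bears on why these groups read as they do.

Compound 4 changes both the substituent and its place on the ring, so the contribution of each remains unresolved. From the compounds shown here alone, how a methoxy group, an amine or a carboxylic acid on this ring would read in this assay also stays open.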